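Nitro in place of halogen on the outer ring

A few compounds are considered here, and "the series" means these few. Any claim that something is new, unique, unknown or untested is made for them only; others in the source may bear on it.

Among the measured compounds shown here, compound 3 `COc1cc(CC(O)c2ccc(-c3ccc(Br)cc3)cc2)c([N+](=O)[O-])cc1OC` gives 4300 nM in an ADME assay on HeLa Rh cells (Homo sapiens) for cytotoxicity, read by microscopy (a lower number here means that less compound is tolerated, a higher number that more compound is tolerated), the lowest of the three numbers so far. Compound 2 `COc1cc(CC(O)c2ccc(-c3ccc(F)cc3)cc2)c([N+](=O)[O-])cc1OC` gives 4500 nM in this assay, and the step of a 1.0-fold lower number from compound 2 to compound 3 (0.02 log units; within the scatter) lies within the scatter, so the two stand together. Compound 1 `COc1cc(CC(O)c2ccc(-c3ccc([N+](=O)[O-])cc3)cc2)c([N+](=O)[O-])cc1OC` gives 21000 nM in this assay; the steps of a 4.7-fold lower number from compound 1 to compound 2 (0.67 log units; beyond the scatter) and a 4.9-fold lower number from compound 1 to compound 3 (0.69 log units; beyond the scatter) are both beyond the scatter and both run from a nitro group toward a halogen on the outer ring.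

Compound 4 `COc1cc(CC(O)c2ccc(-c3ccccc3[N+](=O)[O-])cc2)c([N+](=O)[O-])cc1OC` differs from compound 3 by 2-nitrophenyl in place of 4-bromophenyl on an aromatic carbon. The step that bears on this is a 4.9-fold lower number from compound 1 to compound 3 (0.69 log units; beyond the scatter), which removed a nitro group from the outer ring in favour of bromo; compound 4 runs the other way, putting a nitro group back on that ring, though as 2-nitrophenyl rather than in the arrangement of compound 1. The measured steps give no direct reading on that arrangement, so the expectation is a higher number for compound 4 than for compound 3, of roughly the size of the step from compound 1 to compound 3 but with wide uncertainty. Compound 4 is expected to give 12000 nM in this assay, within 4000 nM to 35000 nM. This estimate corresponds to an expected step of a 2.8-fold higher number from compound 3 to compound 4 (0.45 log units; beyond the scatter).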

Compound 4, half-maximal cytotoxic concentration: 9500 nM
The estimate for compound 4 lay 1.3-fold (0.10 log units) above the measured number; low and high end bracket the measured number.
By their numbers in this assay, from the lowest: compounds 3 and 2 (each within the scatter of the next); then compound 4; then compound 1.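

In this assay the nitro group on the outer ring no longer reads as a single change: 2-nitrophenyl and 4-nitrophenyl separate (a 2.2-fold lower number from compound 1 to compound 4 (0.34 log units; beyond the scatter)), so the place of the nitro group on that ring matters to the number as well as its presence. Compound 4 also stays apart from both halogen compounds (a 2.2-fold higher number from compound 3 to compound 4 (0.34 log units; beyond the scatter); a 2.1-fold higher number from compound 2 to compound 4 (0.32 log units; beyond the scatter)), which sets 2-nitrophenyl between the two halogen-bearing groups and 4-nitrophenyl, with each gap beyond the scatter. Nothing available bears on what lies behind this order, which stands as an observation on these four compounds only.

Open, on these data alone, is whether halogens would also shift the number with their place on the outer ring, since 4-bromophenyl and 4-fluorophenyl share one arrangement and the series offers no second one for comparison. Also open, as far as these compounds go, is where an amine or a carboxylic acid on the outer ring would fall in this assay relative to the nitro and halogen compounds, and whether either group would stand outside the range these four compounds span.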